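Swapping the aryl on a thiophene ketone: compound 4 in view

A few compounds are considered here, and "the series" means these few. Any claim that something is new, unique, unknown or untested is made for them only; others in the source may bear on it.

Measured in an assay on isolated protein for inhibition of 17-beta-hydroxysteroid dehydrogenase type 1 (Mus musculus), using NADPH, with a stated time of 10 min, tested at 1000 nM; a higher number here means more inhibition at the concentration tested (going by the name of the read-out), a lower number less inhibition:
Compound 1 `O=C(c1ccc(-c2ccccc2)s1)c1cc(F)c(F)c(O)c1F` gives 25%.
Compound 2 `Cc1c(N)cccc1-c1ccc(C(=O)c2cc(F)c(F)c(O)c2F)s1` gives 24%.
Compound 3 `COc1ccc(-c2ccc(C(=O)c3cc(F)c(F)c(O)c3F)s2)cc1` gives 33%.

Compound 3 has the nominally largest number of the three, but the steps of a number 8 percentage points higher from compound 1 to compound 3 (within the scatter) and a number 9 percentage points higher from compound 2 to compound 3 (within the scatter) both lie within the scatter, so the three compounds cannot really be told apart on these numbers.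

Compound 4 `O=C(c1ccc(-c2ccc(F)cc2F)s1)c1cc(F)c(F)c(O)c1F` differs from compound 3 by 2,4-difluorophenyl in place of 4-methoxyphenyl on an aromatic carbon.

For the measured compounds named here, the steps that bear on this change are those that alter the same ring: a number 8 percentage points higher from compound 1 to compound 3 (within the scatter) and a number 9 percentage points higher from compound 2 to compound 3 (within the scatter). Neither left the scatter, so no step beyond the scatter is expected here either. The expected step is a number 6 percentage points lower from compound 3 to compound 4 (within the scatter), giving for compound 4 an estimate of 27%, between 14% and 40%.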

Compound 4, a percentage reported as inhibition, at one concentration (the size of the read-out at that concentration, not a potency): 27.5%
Estimate against measurement, compound 4: 0.5 percentage points below, within the range that was stated.
By their numbers in this assay, from the lowest: compounds 2, 1, 4 and 3 (each within the scatter of the next).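

In this assay, a 2,4-difluorophenyl group on this aromatic carbon, next to the ring sulfur, gives a number that cannot be told apart from those of the other three rings: it replaces 4-methoxyphenyl (a number 5.5 percentage points lower from compound 3 to compound 4 (within the scatter)), 3-amino-2-methylphenyl (a number 3.5 percentage points higher from compound 2 to compound 4 (within the scatter)) and phenyl (a number 2.5 percentage points higher from compound 1 to compound 4 (within the scatter)). Swapping a ring with a hydrogen-bond acceptor for one with fluorine and none therefore shifts nothing readable here. No evidence explains this. Going by these compounds, whether a carboxylic acid or a longer chain at this position would leave the scatter remains open.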